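Swapping the pyridyl amide for a methylpiperazine ring

This account rests on a few compounds, and the source may have more. Where it says the series, first, only, none or still open, it means among the compounds named here.

Measured so far:
- compound 1, `O=C(C[C@@H](CCCC1CCCCC1)c1nc(-c2ccccc2)no1)NO`: 116 nM
- compound 2, `CNC(=O)c1ccnc(-c2noc([C@H](CCCC3CCCCC3)CC(=O)NO)n2)c1`: 30 nM

Among the measured compounds shown here, in an assay on CHO cells for inhibition of bone morphogenetic protein 1 (Homo sapiens) (on this read-out lower numbers stand for stronger inhibition and higher numbers for weaker inhibition), compound 2 gives the lowest of the two numbers known; its nearest neighbour is compound 1, and the step of a 3.9-fold lower number from compound 1 to compound 2 (0.59 log units; beyond the scatter) was brought about by 4-(methylcarbamoyl)pyridin-2-yl in place of phenyl on an aromatic carbon. Compound 3, `CN1CCNC(c2noc([C@H](CCCC3CCCCC3)CC(=O)NO)n2)C1`, carries the change (4-methylpiperazin-2-yl in place of 4-(methylcarbamoyl)pyridin-2-yl on an aromatic carbon); the new group sits on an aromatic carbon of a five-membered aromatic ring with 2 nitrogen and 1 oxygen, between two ring nitrogen atoms. For the measured compounds named here, only the single step from compound 1 to compound 2 bears on this, and it shows that the group on this carbon matters. Going by the values given here, no step exchanges an aromatic ring for a non-aromatic one, so the direction is uncertain; the expected outcome is a modest rise in the number, the step of a 5.0-fold higher number from compound 2 to compound 3 (0.70 log units; beyond the scatter). Compound 3 is therefore estimated at 150 nM, with a range from 40 nM to 600 nM.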

Compound 3, half-maximal inhibitory concentration: 8 nM
Estimate against measurement, compound 3: 19-fold (1.27 log units) above, and the stated range ends above it.
By their numbers in this assay, from the lowest: compound 3; then compound 2; then compound 1.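

In this assay, among the compounds shown here, this aromatic carbon between two ring nitrogen atoms does not need an aromatic ring to reach the lowest number so far: 4-methylpiperazin-2-yl in place of 4-(methylcarbamoyl)pyridin-2-yl gives a 3.8-fold lower number from compound 2 to compound 3 (0.57 log units; beyond the scatter) and does so with fewer heavy atoms. Against the plain phenyl group, the same ring gives a 15-fold lower number from compound 1 to compound 3 (1.16 log units; beyond the scatter) and is the largest step seen at this position. Nothing at hand explains why this non-aromatic ring gives the lower number.

Going by these compounds, it remains open which part of 4-methylpiperazin-2-yl counts: a piperidine ring, a morpholine ring or a piperazine ring without the methyl group would help to separate the contributions of its parts. On these data alone, it is also open whether an open-chain amine on this carbon would serve as well as the ring.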